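Pyridin-2-yl for 4-fluorophenyl on the pyrazole nitrogen

The source may hold more compounds than are shown below. What is called first, only, known or untested is meant among the compounds shown, and "the series" means these compounds.

The study measures inhibition of myeloperoxidase in an assay on isolated protein for inhibition of Myeloperoxidase (Homo sapiens), with a stated time of 10 min; a lower number here means a stronger inhibitor, a higher number a weaker inhibitor. Three compounds share the same amino-substituted core. Compound 1, `Nc1cc(C2CCNCCc3cccc(c3)OCc3cccc(c3)Cn3cc2cn3)c2nn[nH]c2n1`, gives 17 nM in this assay. Compound 2, `Nc1cc(Cc2ccn(-c3ccc(F)cc3)n2)c2nn[nH]c2n1`, gives 53 nM, and compound 3, `Nc1cc(Cc2ccn(Cc3ccc4c(c3)CCNC4)n2)c2nn[nH]c2n1`, gives 58 nM. Among these three numbers compound 2 stands second highest: its nearest neighbour is compound 3, whose number lies within the scatter of its own, while compound 1 sits furthest away with a number beyond the scatter on the lower side.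

Compound 4, `Nc1cc(Cc2ccn(-c3ccccn3)n2)c2nn[nH]c2n1`, has not yet been measured. It differs from compound 2 in one place: pyridin-2-yl in place of 4-fluorophenyl on an aromatic nitrogen. Going by the values given here, no pair of measured compounds shows this kind of step, so its size cannot be read from the data. Compound 2 and compound 3, which carry quite different groups on the same aromatic nitrogen, give numbers within the scatter of each other, which suggests that this position tolerates change. Compound 4 is therefore expected to give 70 nM in this assay, within a range from 25 nM to 200 nM. The expected step of a 1.3-fold higher number from compound 2 to compound 4 (0.12 log units; within the scatter) is estimated to stay within the scatter.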

Compound 4, half-maximal inhibitory concentration: 54 nM
Beside the measured number, compound 4's estimate is 1.3-fold (0.11 log units) above it; the measured number falls inside the stated range.
By their numbers in this assay, from the lowest: compound 1; then compounds 2, 4 and 3 (each within the scatter of the next).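

In this assay, going by these compounds alone, pyridin-2-yl in place of 4-fluorophenyl on the aromatic nitrogen gives a 1.0-fold higher number from compound 2 to compound 4 (0.01 log units; within the scatter), the first step at this position that can be read between two compounds differing in one place. The position therefore accepts a six-membered aromatic ring with a ring nitrogen and one hydrogen-bond acceptor as well as a carbon-only ring bearing fluorine, with the two numbers staying within the scatter of each other. Nothing among the data shown accounts for this result.

The compounds shown leave open how an amine or a carboxylic acid carried on this six-membered ring would read in this assay. They also leave open whether a methyl group alone on the aromatic nitrogen, with no ring at all, would stay within the scatter of compound 2.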